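A few compounds are considered here, and "the series" means these few. Any claim that something is new, unique, unknown or untested is made for them only; others in the source may bear on it.

- Compound 1 `COC[C@H](C)[C@H](C)C(c1ccc(O)c(OC)c1)c1ccc(O)c(OC)c1`: 82000 nM
- Compound 2 `COC[C@H](C(C)C)C(c1ccc(O)c(OC)c1)c1ccc(O)c(OC)c1`: 72000 nM
- Compound 3 `COC[C@H](C)[C@@H](C)C(c1ccc(O)c(OC)c1)c1ccc(O)c(OC)c1`: 68000 nM

All three were tested in a functional assay on HL-60 cells (Homo sapiens) for cytotoxicity, read by WST assay, with a stated time of 48 h; on this read-out lower numbers stand for stronger inhibition and higher numbers for weaker inhibition. Compound 3, at 68000 nM, stands within the scatter of the other two. Compound 4 `COc1cc(C(c2ccc(O)c(OC)c2)[C@H](CF)C(C)C)ccc1O` changes its side chain: 1-(fluoromethyl)-2-methylpropyl in place of 2-(methoxymethyl)-1-methylpropyl on a saturated chain carbon bound to two aromatic carbons.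

The measured steps rearrange the chain or alter one stereocentre: a 1.1-fold lower number from compound 1 to compound 2 (0.06 log units; within the scatter), a 1.1-fold lower number from compound 2 to compound 3 (0.02 log units; within the scatter) and a 1.2-fold lower number from compound 1 to compound 3 (0.08 log units; within the scatter). Going by these compounds, all of them stay within the scatter, but none replaces a methoxymethyl arrangement with a fluoromethyl one, so that part remains untested. On these small steps, the expected change is a 1.1-fold lower number from compound 3 to compound 4 (0.05 log units; within the scatter), with nothing beyond the scatter anticipated. Compound 4 is estimated at 60000 nM, with an expected range of 25000 nM to 130000 nM.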

Compound 4, half-maximal inhibitory concentration: 19000 nM
The estimate for compound 4 lay 3.2-fold (0.50 log units) above the measured number, outside the stated range (below it).
By their numbers in this assay, from the lowest: compound 4; then compounds 3, 2 and 1 (each within the scatter of the next).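

Unlike the earlier rearrangements of the chain or of one stereocentre, this change moves the number in this assay beyond the scatter, with a 3.6-fold lower number from compound 3 to compound 4 (0.55 log units; beyond the scatter) and a 3.8-fold lower number from compound 2 to compound 4 (0.58 log units; beyond the scatter) and a 4.3-fold lower number from compound 1 to compound 4 (0.64 log units; beyond the scatter) as modest steps. The side chain on this saturated chain carbon bound to two aromatic carbons can therefore alter the read-out when fluoro stands in place of methoxy. Nothing available explains why this change has that result.

Still open, going by these compounds, is whether fluoro itself matters or only the loss of methoxy. A hydroxyl or a plain methyl in place of fluoro would help separate the two.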